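Pyridine Amide to Carboxylic Acid on a Shared Core

The compounds below may be only part of what the source reports. "The series", "measured", "known", "first", "only" and "open" are said of these compounds alone.

Compound 1 `COc1ccc(-c2nc(N=C(N)N)sc2-c2ccc(OC)cc2)cc1` gives 2 uM in a functional assay (aorta) with Rattus norvegicus as the target; on this read-out higher numbers stand for an effect only at larger amounts of compound and lower numbers for an effect already at smaller amounts. Compound 2 `COc1ccc(-c2nc(CNC(=O)c3cccnc3)sc2-c2ccc(OC)cc2)cc1`, measured in this assay, gives 8.2 uM. For the measured compounds named here, the single measured step, a 4.1-fold higher number from compound 1 to compound 2 (0.61 log units; beyond the scatter), concerns the same place on the shared core that the next change touches. Compound 2 thus stands at the higher of the two numbers, with compound 1 as its nearest neighbour.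

Compound 3 `COc1ccc(-c2nc(CCC(=O)O)sc2-c2ccc(OC)cc2)cc1` differs from compound 2 by carboxymethyl in place of ((pyridin-3-yl)carbonyl)amino on a saturated chain carbon bound to an aromatic carbon: the ((pyridin-3-yl)carbonyl)amino group leaves and carboxymethyl enters on a saturated chain carbon bound to an aromatic carbon. Going by the values given here, no measured pair shows this exchange, so the step from compound 1 to compound 2 is the only guide, and it shows a modest shift when this place is altered. The expectation for compound 3 is therefore a step of a 1.5-fold higher number from compound 2 to compound 3 (0.17 log units; within the scatter) in this assay. The estimate for compound 3 is 12 uM, between 3 uM and 45 uM.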

Compound 3, concentration for half-maximal effect: > 100 uM
Compound 3: only a limit was reported (the forecaster's own chance of this, stated with the estimate: 20%); at least 8.3-fold (0.92 log units) between middle value and limit.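

Compound 3 carries only a limit in this assay, not a number: the limit of > 100 uM in this assay, at which 1 of the 3 values shown sits. Even as a limit it marks a far larger change at this place than the earlier pair showed, with carboxymethyl in place of ((pyridin-3-yl)carbonyl)amino giving an at least 12-fold higher number from compound 2 to compound 3 (1.08 log units; beyond the scatter), and the whole exchange on the core of compound 1 giving an at least 50-fold higher number from compound 1 to compound 3 (1.69 log units; beyond the scatter). The place that had moved the number only modestly, with a 4.1-fold higher number from compound 1 to compound 2 (0.61 log units; beyond the scatter), can therefore shift it much further, depending on the group it carries.

From the compounds shown here alone, how far the true value of compound 3 lies past its limit remains unknown. The compounds shown also do not separate the effect of the carboxylic acid from that of losing the pyridine ring and amide, a question that an amine on the same chain or an amide without the pyridine ring could address.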